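Three Aryl Amides and Sulfonamides, One Untested Sulfonamide

The source may report more compounds than this note shows. Statements on the series, on what has been measured and on what is new or still open speak of the compounds shown alone.

Measured so far:
compound 1, `CC(=O)c1ccc(OCCCN2CC[C@H](NC(=O)c3ccc(C#N)cc3)C2)cc1`, 6100 nM
compound 2, `O=C(c1ccc(OCCCN2CC[C@H](NS(=O)(=O)c3ccc(F)cc3)C2)cc1)C1CC1`, 500 nM
compound 3, `CC(=O)c1ccc(OCCCN2CC[C@H](NC(=O)c3csc(-c4cccnc4)n3)C2)cc1`, 6200 nM

In an assay on isolated protein for binding affinity to histamine H2 receptor (Homo sapiens) (a lower number here means a stronger inhibitor, a higher number a weaker inhibitor), compound 2 gives 500 nM, the lowest of the three numbers, so it is the strongest of the measured compounds. Compound 1 gives 6100 nM and compound 3 gives 6200 nM, and each of those stands beyond the scatter above compound 2. Among the compounds with values here, none of the three measured compounds differs from another in only one place, so no single measured step is available to guide the next comparison.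

Compound 4, `Cc1ccccc1S(=O)(=O)N[C@H]1CCN(CCCOc2ccc(C(=O)C3CC3)cc2)C1`, is the compound still to be measured. It differs from compound 2 by 2-methylphenyl in place of 4-fluorophenyl on a sulfonyl sulfur. Within the data shown here, the data contain no measured pair in which one aryl group on a sulfonyl sulfur is exchanged for another, so there is no step of this kind to read from. The step from compound 2 to compound 4 in this assay is therefore expected to be small, in either direction or none beyond the scatter, and the estimate is a 1.4-fold higher number from compound 2 to compound 4 (0.15 log units; within the scatter). Compound 4 is accordingly expected to give about 700 nM, within a range from 200 nM to 2500 nM.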

Compound 4, inhibition constant: 2200 nM
Beside the measured number, compound 4's estimate is 3.1-fold (0.50 log units) below it, and the stated range covers the measured number.
By their numbers in this assay, from the lowest: compound 2; then compound 4; then compounds 1 and 3 (each within the scatter of the next).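

In this assay, within the data shown here, placing 2-methylphenyl in place of 4-fluorophenyl on a sulfonyl sulfur gives a 4.4-fold higher number from compound 2 to compound 4 (0.64 log units; beyond the scatter) and is the first single-place comparison in the set, showing that the number at this position depends on which aryl group the sulfonyl sulfur carries. The step appears even though the two groups match in heavy-atom count, each has one six-membered aromatic ring of carbon only, and neither has a hydrogen-bond donor, a hydrogen-bond acceptor or a net charge, so those counted features do not distinguish them. Nothing available explains why this exchange raises the number.

Because the exchange removes fluorine and adds methyl in one step, the pair cannot show how much each change contributes, and a plain phenyl group or a pyridine ring on the sulfonyl sulfur would be needed to separate them or to test the position more widely. Steps involving compound 1 or compound 3 cannot be read, as each differs from the other compounds in more than one place, so the effect of replacing the sulfonamide with an amide also remains open.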